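A few compounds are considered here, and "the series" means these few. Any claim that something is new, unique, unknown or untested is made for them only; others in the source may bear on it.

The data on this series are sparse, with only two entries in a functional assay on SMMC-7721 cells (Homo sapiens) for antiproliferative activity, read by CCK-8 assay, with a stated time of 72 h; a higher number here means a weaker inhibitor, a lower number a stronger inhibitor. Compound 1 (`CCc1ccc(SCc2ccc(/C=C/C(=O)Nc3ccccc3N)cc2)cc1`) has no usable result, and its entry reads "not determined" (no result reported). For the measured compounds named here, compound 2 (`COc1ccc(SCc2ccc(C(=O)Nc3ccccc3N)cc2)cc1`) gives 2170 nM, the only number available, so it cannot be ranked against any other compound. Going by the values given here, no measured step between two compounds exists either, so the data do not show how strongly a small change moves the read-out.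

The next compound to be tested is compound 3 (`CCc1ccc(SCc2ccc(C(=O)Nc3ccccc3N)cc2)cc1`), which differs from compound 2 in one place: ethyl in place of methoxy on an aromatic carbon. The 4-methoxyphenyl of compound 2 becomes a 4-ethylphenyl in compound 3, while the rest of the structure stays the same.

With so little to go on, no step beyond the scatter is expected in this assay, and no firm direction can be given. The estimated change, a 1.1-fold lower number from compound 2 to compound 3 (0.04 log units; within the scatter), is therefore small. For compound 3 the expected half-maximal inhibitory concentration is 2000 nM, with an estimated range from 900 nM to 4500 nM.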

Compound 3, half-maximal inhibitory concentration: 1750 nM
For compound 3 the middle estimate is 1.1-fold (0.06 log units) above the measured one; measured number inside the range.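

For the compounds shown here, the exchange of 4-methoxyphenyl for 4-ethylphenyl in this assay gives a 1.2-fold lower number from compound 2 to compound 3 (0.09 log units; within the scatter) and provides the first measured step. It shows that, on this aromatic carbon para to a large group, replacing methoxy, with its hydrogen-bond acceptor, by ethyl, with none, leaves the antiproliferative read-out within the usual scatter of repeated measurements, so the oxygen of methoxy is not required to keep the read-out at this level in this pair. No available measurement bears on why the two compounds read alike.

Whether any other group at this position would move the read-out beyond the scatter remains open, since an amine, a carboxylic acid and a longer chain such as butyl are not among the compounds shown. Compound 1 carries the same 4-ethylphenyl as compound 3 but has no number, so the effect of its different core cannot be read.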